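Benzyl swap in a series held at the assay limit

The source may report more compounds than this note shows. Statements on the series, on what has been measured and on what is new or still open speak of the compounds shown alone.

Measured so far in a functional assay on NIH3T3 cells (Mus musculus); a lower number here means that less compound is needed, a higher number that more compound is needed for the effect:
compound 1 `N#Cc1ccc(Cn2cncc2CNc2ccc(C(=O)Nc3cccc([N+](=O)[O-])c3)c(-c3ccccc3)c2)cc1`, reported only as the limit > 10 uM.
compound 2 `COC(=O)[C@H](CCSC)NC(=O)c1ccc(NCc2cncn2Cc2cccc(C#N)c2)cc1-c1ccccc1`, reported only as the limit > 10 uM.
compound 3 `CSCNC(=O)c1ccc(NCc2cncn2Cc2ccc(C#N)cc2)cc1-c1ccccc1`, reported only as the limit > 10 uM.

Compound 2 stands at the limit, not at a number, and every value shown in this assay sits there: the limit of > 10 uM in this assay, at which 3 of the 3 values shown sit. Going by the values given here, the one change that can be compared, a step that the two limits leave unreadable from compound 1 to compound 3, is unreadable for the same reason, so no size and no direction has been seen anywhere.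

Compound 4 `COC(=O)[C@H](CCSC)NC(=O)c1ccc(NCc2cncn2Cc2ccccc2Cl)cc1-c1ccccc1` differs from compound 2 in one place: 2-chlorophenyl in place of 3-cyanophenyl on a saturated chain carbon bound to an aromatic nitrogen.

Among the compounds with values here, no measured step touches this part of the molecule, and the single step known, from compound 1 to compound 3, concerns the amide-type nitrogen and is in any case unreadable. There is therefore no basis for expecting a step of readable size in this assay in either direction; the likeliest outcome is that compound 4 is also reported only as a limit. As a working estimate, compound 4 is expected to give 20 uM, within 5 uM to 80 uM, which means an expected step that the limit leaves unreadable from compound 2 to compound 4, with the range kept wide because nothing beyond the limit is known for compound 2.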

Compound 4, concentration for half-maximal effect: > 10 uM
Compound 4 ended at the assay's limit; the forecaster's own chance of this, stated with the estimate: 75%; the middle value does not contradict the limit.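

The change from 3-cyanobenzyl to 2-chlorobenzyl between compound 2 and compound 4 gives no readable step in this assay, and the whole series stays at one limit: the limit of > 10 uM in this assay, at which 4 of the 4 values shown sit.

The compounds shown leave open whether any change to the shared core or its groups brings a value within the range of this assay, and in which direction.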